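The source may report more compounds than this note shows. Statements on the series, on what has been measured and on what is new or still open speak of the compounds shown alone.

Measured so far in an assay on isolated protein for inhibition of malate dehydrogenase, mitochondrial (Sus scrofa), with stated times of 45 min and 30 min; a lower number here means a stronger inhibitor, a higher number a weaker inhibitor:
compound 1, `Cc1ccccc1S(=O)(=O)Nc1ccc2oc(-c3ccccc3)nc2c1`: > 63000 nM
compound 2, `COc1ccc(Cl)cc1S(=O)(=O)Nc1ccc2oc(-c3ccccc3)nc2c1`: > 63000 nM
compound 3, `Cc1ccccc1S(=O)(=O)Nc1ccc(-c2nc3ccccc3o2)cc1`: > 63000 nM

In this assay compound 1 gives > 63000 nM, which is a limit of the assay rather than a number. Compound 2 returns > 63000 nM, again a limit. Compound 3 stands at > 63000 nM, also a limit. For the measured compounds named here, the position of the whole set is summed up by the limit of > 63000 nM in this assay, at which 3 of the 3 values shown sit: no compound reached a measurable inhibitory concentration.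

Compound 2 differs from compound 1 by 5-chloro-2-methoxyphenyl in place of 2-methylphenyl on a sulfonyl sulfur. The step that the two limits leave unreadable from compound 1 to compound 2 is left unreadable by the two limits. Compound 3 carries the same atoms as compound 1 joined differently; the difference between the two cores is not broken down here.

Compound 4, `COc1ccc(Cl)cc1S(=O)(=O)Nc1ccc(-c2nc3ccccc3o2)cc1`, has not yet been measured in this assay. It differs from compound 3 by 5-chloro-2-methoxyphenyl in place of 2-methylphenyl on a sulfonyl sulfur, the same change as from compound 1 to compound 2; among the compounds shown it occurs twice in all, with the two places described in identical words. The step expected is a step that the limit leaves unreadable from compound 3 to compound 4, a step of no readable size, most likely ending again at the limit. Going by the values given here, this rests on the step that the two limits leave unreadable from compound 1 to compound 2 being unreadable and on every value so far sitting at the limit, as the limit of > 63000 nM in this assay, at which 3 of the 3 values shown sit, records. Compound 4 is therefore estimated at 100000 nM, with an expected range from 40000 nM to 300000 nM.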

Compound 4, half-maximal inhibitory concentration: > 63000 nM
Compound 4: a limit, no number (the forecaster's own chance of this, stated with the estimate: 85%); the middle value does not contradict the limit.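

In this assay compound 4 gives > 63000 nM, which is a limit of the assay and not a number. No step can be read from compound 3 to compound 4, since both values are limits: the limit of > 63000 nM in this assay, at which 4 of the 4 values shown sit.

The compounds shown leave open whether 5-chloro-2-methoxyphenyl in place of 2-methylphenyl changes inhibition at all, and whether any compound in this series reaches a measurable inhibitory concentration in this assay.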